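Cytotoxicity notes on compound 4

The source may report more compounds than this note shows. Statements on the series, on what has been measured and on what is new or still open speak of the compounds shown alone.

Three members of the series have been run in an ADME assay on MT4 cells (Homo sapiens) for cytotoxicity, read by MTT assay; on this read-out lower numbers stand for higher toxicity in this test and higher numbers for lower toxicity in this test. Compound 1 `Cc1cc(C)cc(S(=O)(=O)c2c(C(=O)NC(C)C(=O)NC(C)c3ccncc3)[nH]c3ccc(Cl)cc23)c1` gives 21900 nM; compound 2 `Cc1cc(C)cc(S(=O)(=O)c2c(C(=O)NCC(=O)NC(C)c3ccccc3)[nH]c3ccc(Cl)cc23)c1` gives 29400 nM; compound 3 `Cc1cc(C)cc(S(=O)(=O)c2c(C(=O)NC(C)C(=O)NCc3ccncc3)[nH]c3ccc(Cl)cc23)c1` gives 19500 nM. On these numbers compound 1 stands second highest of the three, with compound 3 nearest and compound 2 furthest, both within the scatter, so this assay does not separate the three.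

Compound 4 `Cc1cc(C)cc(S(=O)(=O)c2c(C(=O)NC(C)C(=O)NCc3ccncn3)[nH]c3ccc(Cl)cc23)c1` is not yet measured. It differs from compound 1 in one place: (pyrimidin-4-yl)methyl in place of 1-(pyridin-4-yl)ethyl on an amide-type nitrogen. Among the compounds with values here, two measured steps bear on this change. The step of a 1.1-fold lower number from compound 1 to compound 3 (0.05 log units; within the scatter) covers the loss of the methyl on the saturated chain carbon. The step of a 1.5-fold lower number from compound 2 to compound 3 (0.18 log units; within the scatter) covers an exchange of one six-membered aromatic ring for another carrying a hetero atom. Neither moved this assay beyond the scatter, and the change to compound 4 combines both kinds of edit. Compound 4 is therefore expected to move little: a 1.0-fold lower number from compound 1 to compound 4 (0.02 log units; within the scatter). Compound 4 is estimated at 21000 nM, with a range of 11000 nM to 40000 nM.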

Compound 4, half-maximal cytotoxic concentration: 28100 nM
Compound 4: the middle estimate sits 1.3-fold (0.13 log units) below what was measured, within the range that was stated.
By their numbers in this assay, from the lowest: compounds 3, 1, 4 and 2 (each within the scatter of the next).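

In this assay, within the data shown here, the step of a 1.4-fold higher number from compound 3 to compound 4 (0.16 log units; within the scatter) isolates pyrimidin-4-yl in place of pyridin-4-yl, an exchange of ring alone that the earlier compounds did not cover, and it stays within the scatter. The whole change on the amide-type nitrogen, (pyrimidin-4-yl)methyl in place of 1-(pyridin-4-yl)ethyl, gives a 1.3-fold higher number from compound 1 to compound 4 (0.11 log units; within the scatter) and so also stays within the scatter. The pyrimidin-4-yl ring also matches the carbon-only ring group, with a 1.0-fold lower number from compound 2 to compound 4 (0.02 log units; within the scatter) as the step, so no group shown at this position separates from another in this test.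

As far as these compounds go, whether a carboxylic acid, an amine or a longer chain on this amide-type nitrogen would move the number beyond the scatter remains open. No supporting data are available to explain these values.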